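Aryl amide variation in a weakly antiproliferative series

This account rests on a few compounds, and the source may have more. Where it says the series, first, only, none or still open, it means among the compounds named here.

Compound 1 `O=C(Nc1ccc(Cl)c(-c2nnc3c(Cl)cccn23)c1)c1c(F)cccc1Cl` — 57600 nM
Compound 2 `O=C(Nc1ccc(Cl)c(-c2nnc3c(Cl)cccn23)c1)c1ccccc1Cl` — > 100000 nM
Compound 3 `Cc1cc(Cl)ccc1C(=O)Nc1ccc(Cl)c(-c2nnc3c(Cl)cccn23)c1` — 34300 nM

In a functional assay on MDA-MB-468 cells (Homo sapiens) for antiproliferative activity, read by MTT assay, with a stated time of 72 h (on this read-out lower numbers stand for stronger inhibition and higher numbers for weaker inhibition), compound 1 gives 57600 nM. For compound 2 the result is only a limit of the assay, > 100000 nM (the limit of > 100000 nM in this assay, at which 1 of the 3 values shown sits). Compound 3 gives 34300 nM, the lowest of the two actual numbers, although the change a 1.7-fold lower number from compound 1 to compound 3 (0.23 log units; within the scatter) stays within the scatter; the change an at least 2.9-fold lower number from compound 2 to compound 3 (0.46 log units; beyond the scatter) is the only one here that goes beyond it. All three measured compounds share one core and differ only in the aryl group on the carbonyl carbon.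

Compound 4 `CS(=O)(=O)c1ccc(C(=O)Nc2ccc(Cl)c(-c3nnc4c(Cl)cccn34)c2)cc1` has not yet been measured. It differs from compound 3 by 4-(methylsulfonyl)phenyl in place of 4-chloro-2-methylphenyl on a carbonyl carbon. The two measured steps that bear on this position gave, at most, modest shifts, so compound 4 is expected to remain in the same weak range, with the step of a 1.7-fold higher number from compound 3 to compound 4 (0.24 log units; within the scatter) estimated to lie close to or just beyond the scatter. The estimate for compound 4 is 60000 nM, in a range from 20000 nM to 150000 nM, with a real chance that only a limit is reported.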

Compound 4, half-maximal inhibitory concentration: > 100000 nM
Compound 4: only a limit was reported (the forecaster's own chance of this, stated with the estimate: 35%); at least 1.6-fold (0.22 log units) between middle value and limit.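

Compound 4 joins compound 2 at a limit of the assay in this assay: the limit of > 100000 nM in this assay, at which 2 of the 4 values shown sit. With 4-(methylsulfonyl)phenyl on the carbonyl carbon, the result is an at least 2.9-fold higher number from compound 3 to compound 4 (0.46 log units; beyond the scatter), so a second change at this position goes beyond the scatter, and both such changes link compound 3 to a compound at the limit. Set against 2-chloro-6-fluorophenyl, the same group gives an at least 1.7-fold higher number from compound 1 to compound 4 (0.23 log units; that floor lies within the scatter), while the step between the two limits cannot be read.

On these data alone, how far compound 2 and compound 4 lie past the limit stays open, as does whether the chloro or the methyl of 4-chloro-2-methylphenyl matters more. Also open, as far as these compounds go, is what an amine, a carboxylic acid or a longer chain on this aryl ring would give.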